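Flipping one chain stereocentre: from compound 3 to compound 4

A few compounds are considered here, and "the series" means these few. Any claim that something is new, unique, unknown or untested is made for them only; others in the source may bear on it.

Measured so far in an assay on HEK293 cells for agonist activity at putative P2Y purinoceptor 10 (Mus musculus), with a stated time of 1 h; on this read-out lower numbers stand for smaller maximal responses and higher numbers for larger maximal responses:
compound 1 `CCCCCCCC/C=C\CCCCCCCC(=O)OC[C@@H](C)OP(=O)(O)OC[C@H](N)C(=O)O` gives 12.4%
compound 2 `CCCCCCCC/C=C\CCCCCCCC(=O)OC[C@H](C)OP(=O)(O)OC[C@H](N)C(=O)O` gives 11.3%
compound 3 `CCCCCCCC/C=C\CCCCCCCC(=O)O[C@H](C)COP(=O)(O)OC[C@H](N)C(=O)O` gives 11.4%

Among these three numbers, compound 3 has the second highest, with compound 2 nearest and compound 1 furthest, and both of those gaps lie within the scatter. Compound 4 `CCCCCCCC/C=C\CCCCCCCC(=O)O[C@@H](C)COP(=O)(O)OC[C@H](N)C(=O)O` has not yet been measured. It differs from compound 3 in one place: the two compounds have the same atoms and bonds; at least one stereo element is drawn with a configuration in one of them and without one in the other: 1 of 4 stereo elements differ; a stereocentre at a saturated chain carbon is drawn R in compound 3 and S in compound 4. Within the data shown here, one measured step bears on this, since the same kind of change separates compound 1 from compound 2: a number 1.1 percentage points lower from compound 1 to compound 2 (within the scatter). No step beyond the scatter is therefore expected in this assay; the expected step is a number 0.1 percentage points higher from compound 3 to compound 4 (within the scatter). Compound 4 is estimated at 11.5%, between 5% and 18%.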

Compound 4, largest response reached (Emax), in percent of the reference or control that the assay uses: 11.6%
Compound 4: middle estimate off by 0.1 percentage points, on the low side; the measured number falls inside the stated range.
By their numbers in this assay, from the lowest: compounds 2, 3, 4 and 1 (each within the scatter of the next).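

In this assay, reversing this saturated chain stereocentre gives a number 0.2 percentage points higher from compound 3 to compound 4 (within the scatter). Compounds 1 and 2 showed this for one pair only; compounds 3 and 4 now add a second pair, and again the drawn configuration at a chain stereocentre leaves no readable mark on the maximal response. Nothing available explains why the response stays flat across this change.

As far as these compounds go, whether this indifference to configuration would hold with a longer chain remains open. So does the effect of replacing the carboxylic acid with an amide, which might move the response beyond the scatter.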